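Working notes: ethyl for cyclopentyl on a ring amine nitrogen

A few compounds are considered here, and "the series" means these few. Any claim that something is new, unique, unknown or untested is made for them only; others in the source may bear on it.

Measured so far in an assay on HEK293 cells for antagonist activity at Toll-like receptor 9 (Homo sapiens), read by spectrophotometry; on this read-out lower numbers stand for stronger inhibition and higher numbers for weaker inhibition:
compound 1 `CCN1CCN(c2nc(NCc3ccc(F)cc3)nc3c2ncn3CCCN2CCCC2)CC1` gives 40 nM
compound 2 `CN(C)Cc1ccc(CNc2nc(N3CCN(C4CCCC4)CC3)c3ncn(CCCN4CCCC4)c3n2)cc1` gives 7 nM
compound 3 `COc1ccc(CNc2nc(N3CCN(C4CCCC4)CC3)c3ncn(CCCN4CCCC4)c3n2)cc1` gives 240 nM

Compound 2 stands at the lowest number of the three in this assay; compound 1 is nearest to it and compound 3 furthest, with both gaps beyond the scatter. Among the measured compounds shown here, the only step between compounds that differ in a single place is a 34-fold higher number from compound 2 to compound 3 (1.54 log units; beyond the scatter), a change at the aromatic carbon and not at the ring nitrogen.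

Compound 4 `CCN1CCN(c2nc(NCc3ccc(CN(C)C)cc3)nc3c2ncn3CCCN2CCCC2)CC1` is not yet measured. It differs from compound 2 by ethyl in place of cyclopentyl on an amine nitrogen in a ring. For the measured compounds named here, no measured pair isolates this swap: compound 1 carries the ethyl group but also differs from compound 2 at the aromatic carbon, so the two values mix two changes and cannot be read as one step. Going by the values given here, the single measured step concerns the other position and does not bear on the ring nitrogen. With nothing anchoring the direction, the expected step is small, a 2.1-fold higher number from compound 2 to compound 4 (0.33 log units; beyond the scatter), within or near the scatter. Compound 4 is therefore estimated at 15 nM, between 5 nM and 50 nM.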

Compound 4, half-maximal inhibitory concentration in the Toll-like receptor 9 assay: 90 nM
Beside the measured number, compound 4's estimate is 6.0-fold (0.78 log units) below it; the measured number lies above the stated range.
By their numbers in the Toll-like receptor 9 assay, from the lowest: compound 2; then compound 1; then compound 4; then compound 3.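

Working notes, continued: in the Toll-like receptor 9 assay, the change at the ring nitrogen can now be read alone, and ethyl in place of cyclopentyl is not a neutral swap: a 13-fold higher number from compound 2 to compound 4 (1.11 log units; beyond the scatter), a large step that shows the cyclopentyl group on this nitrogen counts for much of what sets compound 2 apart. With ethyl held fixed on that nitrogen, the Toll-like receptor 9 assay gives a 2.3-fold higher number from compound 1 to compound 4 (0.35 log units; beyond the scatter) for (dimethylamino)methyl in place of fluoro, so in this pair the (dimethylamino)methyl group does not bring the lower number, a reading that rests on these two compounds alone. In a physicochemical assay for solubility, with a stated time of 18 h, at pH 7.4 (a higher number here means a more soluble compound, a lower number a less soluble compound), compound 2 gives 47.5 ug/mL and compound 4 gives 136 ug/mL after the change from cyclopentyl to ethyl, with compound 4 the more soluble of the two, so the loss at the receptor comes with a gain in solubility: the measured solubility of compound 2, 47.5 ug/mL, and of compound 4, 136 ug/mL, a 2.9-fold higher number (0.46 log units; beyond the scatter)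

Open, going by these compounds, is whether the number in the Toll-like receptor 9 assay follows the carbon count on this nitrogen or something specific to the ring of cyclopentyl, which isopropyl, cyclobutyl or cyclohexyl there would begin to separate. Also open, on these data alone, is whether a ring carrying oxygen, such as tetrahydropyran-4-yl, could hold the number of compound 2 and still keep the solubility of compound 4.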